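Removing the oxan-2-yl group from compound 2

The source may report more compounds than this note shows. Statements on the series, on what has been measured and on what is new or still open speak of the compounds shown alone.

Measured so far:
compound 1, `COc1ccc(F)cc1-c1cccc(-c2nn(CCCCF)c(=O)o2)c1`, 83%
compound 2, `COc1ccc(F)cc1-c1cccc(-c2nn(CCOC3CCCCO3)c(=O)o2)c1`, 56%

In a functional assay on the whole organism (strain Wistar albino) for inhibition, with Rattus norvegicus as the target, read by paw edema, with stated times of 30 min and 2 h, at a dose of 10 mg/kg by the oral route (a higher number here means more inhibition at the dose given (going by the name of the read-out), a lower number less inhibition), compound 1 gives 83%, and compound 2 gives 56%, the lowest of the two numbers recorded. Among the measured compounds shown here, the one measured step, a number 27 percentage points lower from compound 1 to compound 2 (beyond the scatter), shows that bringing in the (oxan-2-yl)oxy group lowered inhibition of paw edema by a modest but real amount.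

Compound 3, `COc1ccc(F)cc1-c1cccc(-c2nn(CCO)c(=O)o2)c1`, has not been measured. It differs from compound 2 by hydrogen in place of oxan-2-yl on an oxygen on a saturated carbon, so the oxan-2-yl group that arrived in the step to compound 2 leaves again, while the rest of the side chain and the shared core stay as they are. For the measured compounds named here, only the step from compound 1 to compound 2 bears on this change, and it was of modest size. Since that step removed part of the inhibition, taking the oxan-2-yl group away again is expected to recover some of it, though not necessarily all. The 2-hydroxyethyl chain of compound 3 is not the chain of compound 1. Compound 3 is therefore expected to show a step of a number 9 percentage points higher from compound 2 to compound 3 (within the scatter) in this assay, a rise that may stay within the scatter. The estimate for compound 3 is 65%, within 45% to 85%.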

Compound 3, a percentage reported as inhibition, in the whole organism at one dose (the size of the read-out at that dose, not a potency): 69%
Compound 3: the middle estimate sits 4 percentage points below what was measured; low and high end bracket the measured number.
By their numbers in this assay, from the lowest: compound 2; then compound 3; then compound 1.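

In this assay, freeing the oxygen gives a number 13 percentage points higher from compound 2 to compound 3 (beyond the scatter), which isolates the cost of the oxan-2-yl group on this oxygen, something the earlier pair could not do, since compound 1 and compound 2 differ in the whole end of the chain. The recovery is only partial, as the comparison with the fluorinated chain reads a number 14 percentage points lower from compound 1 to compound 3 (beyond the scatter). Removing the oxan-2-yl group therefore does not by itself restore the level of compound 1, and the 2-hydroxyethyl chain of compound 3 takes a place of its own between the other two chains in this series.

Going by these compounds, whether the gain belongs to the hydroxy itself or only to the loss of the oxan-2-yl group stays open, as does what an amine or a carboxylic acid at the end of the same chain would give. Equally open, on these data alone, is whether a longer chain carrying the hydroxy would close the remaining gap to compound 1. No independent data are at hand that would account for either step.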